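The source may hold more compounds than are shown below. What is called first, only, known or untested is meant among the compounds shown, and "the series" means these compounds.

In a functional assay on the whole organism (strain Swiss) with Mus musculus as the target, in the maximal electroshock model, with a stated time of 1 h, at a dose of 300 mg/kg by the intraperitoneal route (a lower number here means a weaker effect, a higher number a stronger effect of the compound at the dose given), compound 1 `COc1cccc(N2CCN(C(=O)C(C)N3C(=O)CCC3=O)CC2)c1` gives 0%. Compound 2 `CCC(C(=O)N1CCN(c2cccc(OC)c2)CC1)N1C(=O)CCC1=O` gives 0%, and compound 3 `CCC(C(=O)N1CCN(c2cccc(F)c2)CC1)N1C(=O)CCC1=O` gives 75%; compound 1 therefore sits level with compound 2, the two together being the lowest of the three numbers. Compound 4 `CC(C(=O)N1CCN(c2ccccc2F)CC1)N1C(=O)CCC1=O` differs from compound 1 by 2-fluorophenyl in place of 3-methoxyphenyl on an amine nitrogen in a ring. For the measured compounds named here, two measured steps bear on this. The step of no change at the digits printed from compound 1 to compound 2 (within the scatter) lies within the scatter. Going by the values given here, the step of a number 75 percentage points higher from compound 2 to compound 3 (beyond the scatter), fluoro in place of methoxy on an aromatic carbon, is large; the present change likewise trades methoxy for fluorine, though as a different whole ring group, so no measured step isolates it exactly. A sizeable rise is expected, a number 40 percentage points higher from compound 1 to compound 4 (beyond the scatter). Compound 4 is estimated at 40%, between 0% and 90%.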

Compound 4, a percentage reported as activity, at one dose (the size of the read-out at that dose, not a potency): 50%
The estimate for compound 4 lay 10 percentage points below the measured number; low and high end bracket the measured number.
By their numbers in this assay, from the lowest: compounds 1 and 2 (each within the scatter of the next); then compound 4; then compound 3.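

In this assay the exchange of 3-methoxyphenyl for 2-fluorophenyl on the amine nitrogen in the ring gives a number 50 percentage points higher from compound 1 to compound 4 (beyond the scatter) and so shows that a fluorine-bearing phenyl group can raise the read-out on the core of compound 1, not only on that of compound 2. Nothing shown here gives a reason for this rise.

From the compounds shown here alone, whether the gain comes from losing the methoxy or from adding the fluorine stays open, as does the result with plain phenyl or 2-chlorophenyl at this nitrogen. Compound 3 and compound 4 differ in two places, so they cannot separate the effect of the side chain from that of where the fluorine sits.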